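This account rests on a few compounds, and the source may have more. Where it says the series, first, only, none or still open, it means among the compounds named here.

Measured so far in a functional assay on HCT-116 cells (Homo sapiens) for cytotoxicity, read by MTT assay, with a stated time of 48 h; on this read-out higher numbers stand for weaker inhibition and lower numbers for stronger inhibition:
compound 1 `CCCCOc1ccc2c(Cl)ccnc2c1` — 2740 nM
compound 2 `CCOc1ccc2c(Cl)ccnc2c1` — 3160 nM
compound 3 `CCOc1ccc2c(NCCN(C)C)ccnc2c1` — 2570 nM

Compound 2 carries the highest of the three numbers in this assay, but the step of a 1.2-fold higher number from compound 1 to compound 2 (0.06 log units; within the scatter) and the step of a 1.2-fold lower number from compound 2 to compound 3 (0.09 log units; within the scatter) both lie within the scatter, so no ordering among the three is claimed.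

Compound 4 `CC(C)Oc1ccc2c(Cl)ccnc2c1` differs from compound 2 by methyl in place of hydrogen on a saturated chain carbon bound to an oxygen on an aromatic ring and a saturated chain carbon. For the measured compounds named here, the one measured step that touches this chain is a 1.2-fold higher number from compound 1 to compound 2 (0.06 log units; within the scatter), which did not move the number beyond the scatter. On that basis the step from compound 2 to compound 4 is expected to be a 1.1-fold lower number from compound 2 to compound 4 (0.02 log units; within the scatter), with no direction beyond the scatter. Compound 4 is therefore estimated at 3000 nM, range 1500 nM to 6300 nM.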

Compound 4, half-maximal inhibitory concentration: 2590 nM
Beside the measured number, compound 4's estimate is 1.2-fold (0.06 log units) above it; measured number inside the range.
By their numbers in this assay, from the lowest: compounds 3, 4, 1 and 2 (each within the scatter of the next).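

In this assay, adding a branch at the saturated chain carbon bound to the oxygen leaves the number within the scatter (a 1.2-fold lower number from compound 2 to compound 4 (0.09 log units; within the scatter)). Exchanging butyl for isopropyl on that oxygen does the same (a 1.1-fold lower number from compound 1 to compound 4 (0.02 log units; within the scatter)), so ethyl, butyl and isopropyl cannot be told apart here, whether the chain is straight or branched. No measurement shown gives a reason for this.

Open, going by these compounds, is whether a longer chain such as octyl, a terminal amine or a carboxylic acid on this oxygen would move the number beyond the scatter.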